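The source may report more compounds than this note shows. Statements on the series, on what has been measured and on what is new or still open speak of the compounds shown alone.

Measured compounds:
compound 1 `Nc1nc(Cl)c2ncn([C@H]3CCC[C@H]3CO)c2n1`, 71400 nM
compound 2 `Nc1nc(Cl)c2nnn([C@H]3CCC[C@H]3CO)c2n1`, 71000 nM
compound 3 `Nc1nc(O)c2ncn([C@H]3CCC[C@H]3CO)c2n1`, > 200000 nM

In a functional assay on L1210 cells (Mus musculus) for antiproliferative activity (a higher number here means a weaker inhibitor, a lower number a stronger inhibitor), compound 1 gives 71400 nM and compound 2 gives 71000 nM; these two sit within the scatter of each other, so compound 2 stands level with compound 1. Compound 3 reaches only a limit in this assay, > 200000 nM. Compound 4 `Nc1nc(O)c2nnn([C@H]3CCC[C@H]3CO)c2n1` is not yet measured; it differs from compound 2 by hydroxy in place of chloro on an aromatic carbon. The same change has been measured once, in an at least 2.8-fold higher number from compound 1 to compound 3 (0.44 log units; beyond the scatter), where the result is bounded by the limit of > 200000 nM in this assay, at which 1 of the 3 values shown sits. A step of at least similar size toward a higher number is therefore expected, and compound 4 is expected to reach that limit as well. Compound 4 is estimated at 250000 nM, between 150000 nM and 600000 nM, which means an expected step of a 3.5-fold higher number from compound 2 to compound 4 (0.55 log units; beyond the scatter).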

Compound 4, half-maximal inhibitory concentration: 80000 nM
The estimate for compound 4 lay 3.1-fold (0.49 log units) above the measured number, outside the stated range (below it).
By their numbers in this assay, from the lowest: compounds 2, 1 and 4 (each within the scatter of the next). At a limit, above all of these: compound 3.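

In this assay, hydroxy in place of chloro on this aromatic carbon does not always raise the number: the step here is a 1.1-fold higher number from compound 2 to compound 4 (0.05 log units; within the scatter). The clear rise seen earlier therefore did not appear on both cores. Whether the change truly acts differently on the two cores remains unsettled: the same change on two cores in this assay, an at least 2.8-fold higher number (0.44 log units; beyond the scatter) from compound 1 to compound 3 and a 1.1-fold higher number (0.05 log units; within the scatter) from compound 2 to compound 4; the limit leaves it open whether they differ

The compounds shown leave open what other groups would do on this aromatic carbon, such as an amine or a methoxy group. They also leave open whether either group would give a lower number than chloro on either core.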